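This account rests on a few compounds, and the source may have more. Where it says the series, first, only, none or still open, it means among the compounds named here.

Measured so far in a functional assay on MCF7 cells (Homo sapiens); a higher number here means a weaker inhibitor, a lower number a stronger inhibitor:
- compound 1 `COc1cc(NC(C)CCCNC(=O)NCCCO)c2ncccc2c1`: 31000 nM
- compound 2 `COc1cc(NC(C)CCCNC(=O)NOCc2ccccc2)c2ncccc2c1`: 9000 nM

Compound 2 stands lowest of the two numbers; the step of a 3.4-fold lower number from compound 1 to compound 2 (0.54 log units; beyond the scatter) separates it from compound 1 and lies beyond the usual scatter. That step is the only measured one, and it came with exchanging a hydroxypropyl chain for a benzyloxy group on the urea nitrogen.

Compound 3 `COc1cc(NC(C)CCCNC(=O)NO)c2ncccc2c1` is not yet measured. It differs from compound 2 as follows: hydrogen in place of benzyl on an oxygen. Among the compounds with values here, the benzyl that accompanied the only improvement seen is thus taken away again, so the single relevant step points in the opposite direction for this change. Since compound 1 gave 31000 nM without any benzyl group, a step back upward is expected, of roughly a 2.8-fold higher number from compound 2 to compound 3 (0.44 log units; beyond the scatter). Compound 3 is therefore estimated at 25000 nM in this assay, with a range from 8000 nM to 80000 nM.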

Compound 3, half-maximal inhibitory concentration: 44000 nM
Estimate against measurement, compound 3: 1.8-fold (0.25 log units) below; the measured number falls inside the stated range.
By their numbers in this assay, from the lowest: compound 2; then compounds 1 and 3 (each within the scatter of the next).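

In this assay the step of a 4.9-fold higher number from compound 2 to compound 3 (0.69 log units; beyond the scatter) shows that taking the benzyl off the oxygen loses the lower number of compound 2, so an oxygen on the amide-type nitrogen does not give that number by itself. The step of a 1.4-fold higher number from compound 1 to compound 3 (0.15 log units; within the scatter) lies within the scatter, so hydroxy and 3-hydroxypropyl cannot be told apart at this position in this assay. Of these three compounds, only compound 2, with its benzyloxy group, stands apart from the others, and no outside measurement helps to explain this.

As far as these compounds go, whether a small methoxy or a longer phenethyloxy group would keep the lower number remains open. So does whether the benzyl needs the oxygen at all, which a benzyl placed directly on the amide-type nitrogen would test.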